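Swapping methylcarbamoyl for bromo on the shared core

The source may hold more compounds than are shown below. What is called first, only, known or untested is meant among the compounds shown, and "the series" means these compounds.

Of the compounds shown here, two built on a shared core have been measured so far in a functional assay on HeLa cells (Homo sapiens) for antiproliferative activity, read by CCK-8 assay, with a stated time of 72 h; a lower number here means a stronger inhibitor, a higher number a weaker inhibitor. In this assay, compound 1 `COc1ccc(-c2cncnc2-c2cc(OC)c(OC)c(OC)c2)cc1F` gives 500 nM. Compound 2 `CNC(=O)c1ccc(-c2cncnc2-c2cc(OC)c(OC)c(OC)c2)cc1` gives 1470 nM, the higher of the two numbers, and its gap to compound 1 lies beyond the usual scatter.

Compound 3 `COc1cc(-c2ncncc2-c2ccc(Br)cc2)cc(OC)c1OC` keeps the core and changes one place: bromo in place of methylcarbamoyl on an aromatic carbon.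

Among the measured compounds shown here, no measured pair isolates this swap, so the size of the step cannot be read directly from the data. The nearest guide is compound 1 at 500 nM, which also lacks the methylcarbamoyl group and has the lower number. Two values are a thin basis, so the expectation is loose. The expected move is modest, a 2.5-fold lower number from compound 2 to compound 3 (0.39 log units; beyond the scatter), toward a lower number and so a stronger inhibitor. For compound 3 the estimated value is 600 nM, with an expected range from 150 nM to 2500 nM.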

Compound 3, half-maximal inhibitory concentration: 500 nM
Compound 3: the middle estimate sits 1.2-fold (0.08 log units) above what was measured, and the stated range covers the measured number.
By their numbers in this assay, from the lowest: compounds 1 and 3 (each within the scatter of the next); then compound 2.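

In this assay, putting bromo in place of methylcarbamoyl on this aromatic carbon gives a 2.9-fold lower number from compound 2 to compound 3 (0.47 log units; beyond the scatter). This is the first direct reading of a single change at this position, and it shows that a group of one heavy atom with no hydrogen-bond donor or acceptor can stand here and still give a lower number than methylcarbamoyl, so among these compounds methylcarbamoyl is not needed for activity. The comparison with the other ring pattern adds a second point, since 4-bromophenyl in place of 3-fluoro-4-methoxyphenyl gives no change at the digits printed from compound 1 to compound 3 (within the scatter), and no measurement shown here explains either step.

From the compounds shown here alone, what stays open is whether the lower number of compound 3 comes from bromo itself or simply from the loss of methylcarbamoyl, a question that a plain hydrogen, a chloro or a methyl at the same place would help to settle. An amine or a carboxylic acid there would show how far the number moves with groups of a quite different kind, and the trend across such a set cannot yet be drawn from three compounds.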